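Methyl on the fused ring of compound 1

A few compounds are considered here, and "the series" means these few. Any claim that something is new, unique, unknown or untested is made for them only; others in the source may bear on it.

Compound 1 `Cc1nnc(SCc2cc(=O)c3ccccc3o2)s1` is measured in a functional assay on LM7 cells (Homo sapiens) for cytotoxicity, read by MTT assay, with a stated time of 72 h; a higher number here means a weaker inhibitor, a lower number a stronger inhibitor. In this assay compound 1 gives > 25000 nM, which is a limit of the assay and not a number. Compound 2 `Cc1nnc(SCc2cc(=O)c3ccccc3o2)o1` gives > 25000 nM in this assay, again a limit. Compound 3 `Nc1nnc(SCc2cc(=O)c3ccccc3o2)s1` gives > 25000 nM in this assay, also a limit. The steps within the measured set are accordingly not readable: a step that the two limits leave unreadable from compound 1 to compound 2, a step that the two limits leave unreadable from compound 1 to compound 3 and a step that the two limits leave unreadable from compound 2 to compound 3. All three changes alter the ring attached to the sulfur; none of them touches the fused ring of carbon only.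

Compound 4 `Cc1ccc2oc(CSc3nnc(C)s3)cc(=O)c2c1` differs from compound 1 by methyl in place of hydrogen on an aromatic carbon. Within the data shown here, no measured step bears on this position, and the measured steps themselves are unreadable, so the set gives no size or direction for the step in this assay. Given (the limit of > 25000 nM in this assay, at which 3 of the 3 values shown sit), the expected outcome for compound 4 is a further limit rather than a number. Compound 4 is therefore estimated at 30000 nM, with a range of 10000 nM to 100000 nM. The step this estimate implies is a step that the limit leaves unreadable from compound 1 to compound 4, expected to stay within the scatter and most likely to be reported only as a limit.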

Compound 4, half-maximal inhibitory concentration: > 25000 nM
Compound 4: no number, only a limit; the forecaster's own chance of this, stated with the estimate: 85%; the middle value is on the limit's open side.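

In this assay, among these compounds, compound 4 gives > 25000 nM, a limit of the assay and not a number, and compound 1 is also held at a limit, so no step between compound 1 and compound 4 can be read. The compounds shown leave open whether any change to this series gives a measurable value in this assay, because every compound sits at the same limit: the limit of > 25000 nM in this assay, at which 4 of the 4 values shown sit.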